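A few compounds are considered here, and "the series" means these few. Any claim that something is new, unique, unknown or untested is made for them only; others in the source may bear on it.

Compound 1 `Brc1cn2ccnc2c(-c2ccc3ncn(C4CCCCC4)c3c2)n1` stands lowest of the two compounds measured in a functional assay on RPMI-8226 cells (Homo sapiens) for inhibition, read by sulforhodamine B assay, with a stated time of 48 h, tested at 10 uM (on this read-out higher numbers stand for more inhibition at the one concentration tested (going by the name of the read-out) and lower numbers for less inhibition), where compound 1 gives 14.9%. For the measured compounds named here, its only measured neighbour, compound 2 `O=Cc1ccc(-c2cn3ccnc3c(-c3ccc4ncn(C5CCCCC5)c4c3)n2)cc1`, gives 82.5%, and the step of a number 67.6 percentage points higher from compound 1 to compound 2 (beyond the scatter) is the single change that bears here. Compound 3 `FC(F)(F)c1cccc(-c2cn3ccnc3c(-c3ccc4ncn(C5CCCCC5)c4c3)n2)c1` differs from compound 1 by 3-(trifluoromethyl)phenyl in place of bromo on an aromatic carbon, again a six-membered aromatic ring in place of bromo on an aromatic carbon. On that one precedent a rise is expected, a number 45.1 percentage points higher from compound 1 to compound 3 (beyond the scatter), though 3-(trifluoromethyl)phenyl is not the 4-formylphenyl of compound 2. Compound 3 is therefore estimated at 60%, within 25% to 90%.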

Compound 3, a percentage reported as inhibition, at one concentration (the size of the read-out at that concentration, not a potency): 32.1%
Beside the measured number, compound 3's estimate is 27.9 percentage points above it, and the stated range covers the measured number.
By their numbers in this assay, from the lowest: compound 1; then compound 3; then compound 2.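

In this assay, a substituted phenyl ring in place of bromo does not by itself give a high reading: there is a number 17.2 percentage points higher from compound 1 to compound 3 (beyond the scatter), but also a number 50.4 percentage points lower from compound 2 to compound 3 (beyond the scatter). At this position, then, the identity of the phenyl ring's substituent, its location on the ring, or both, strongly affect the reading. Nothing available explains the difference. The two phenyl groups differ in both substituent and location, so these effects remain unseparated. From the compounds shown here alone, how a plain phenyl, or a phenyl carrying an amine or a carboxylic acid, would read also remains open.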